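The compounds below may be only part of what the source reports. "The series", "measured", "known", "first", "only" and "open" are said of these compounds alone.

Measured compounds:
Compound 1, `Cc1nc2nc(SCc3ccc(Cl)cc3)nn2c(N2CC[C@@H](C)[C@@H](N(C)c3ncnc4[nH]ccc34)C2)c1C`: > 100000 nM
Compound 2, `Cc1cc(N2CC[C@@H](C)[C@@H](N(C)c3ncnc4[nH]ccc34)C2)n2nc(SCCc3ccccc3)nc2n1`: 28000 nM
Compound 3, `CCc1cc(N2CC[C@@H](C)[C@@H](N(C)c3ncnc4[nH]ccc34)C2)n2ncnc2n1`: 82200 nM

In a functional assay on BGC-823 cells (Homo sapiens) for inhibition, read by MTT assay, with a stated time of 72 h (a higher number here means a weaker inhibitor, a lower number a stronger inhibitor), compound 1 gives only > 100000 nM, which is a limit of the assay and not a number, as the limit of > 100000 nM in this assay, at which 1 of the 3 values shown sits, records. Compound 2 gives 28000 nM, the lowest of the two real numbers. Compound 3 gives 82200 nM, a higher number by a gap that is beyond the usual scatter. Compound 4, `Cc1cc(N2CC[C@@H](C)[C@@H](N(C)c3ncnc4[nH]ccc34)C2)n2nc(SCc3ccc([N+](=O)[O-])cc3)nc2n1`, has not yet been tested in this assay. It differs from compound 2 by 4-nitrophenyl in place of benzyl on a saturated chain carbon bound to a sulfur. Going by the values given here, no single-change step between measured compounds exists to lean on, so the expected step from compound 2 to compound 4 is a 1.6-fold higher number from compound 2 to compound 4 (0.21 log units; within the scatter), a modest move towards a weaker inhibitor, close to the edge of the scatter. Compound 4 is estimated at 45000 nM, with a likely range from 15000 nM to 130000 nM.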

Compound 4, half-maximal inhibitory concentration: 59600 nM
For compound 4 the middle estimate is 1.3-fold (0.12 log units) below the measured one, within the range that was stated.
By their numbers in this assay, from the lowest: compound 2; then compounds 4 and 3 (each within the scatter of the next). At a limit, above all of these: compound 1.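

In this assay, exchanging the phenethyl on the sulfur for 4-nitrobenzyl gives a 2.1-fold higher number from compound 2 to compound 4 (0.33 log units; beyond the scatter), the only single-change step shown. This position therefore responds to a change of group, and this change moves towards a weaker inhibitor. Nothing measured here bears on why the number rises.

From the compounds shown here alone, the step replaces the phenethyl with 4-nitrobenzyl in one move, so the part played by the nitro group alone stays unknown. Going by these compounds, whether an amine or a carboxylic acid on the benzyl ring would give a lower number also stays open.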